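Hydroxyl on the amine chain of compound 3

This account rests on a few compounds, and the source may have more. Where it says the series, first, only, none or still open, it means among the compounds named here.

Three compounds of this series have been run in a functional assay on the whole organism for inhibition, with Nicotiana tabacum as the target; on this read-out higher numbers stand for weaker inhibition and lower numbers for stronger inhibition. Compound 1 `Cc1nc(Nc2ccc(C#N)cc2)c2cc[nH]c2n1` gives 501000000 nM. Compound 2 `CCCNc1[nH]c(C)nc2nccc1-2` gives 339000000 nM. Compound 3 `Cc1nc2nccc-2c(NC(C)C)[nH]1` gives 550000000 nM. Within the data shown here, on these numbers compound 3 sits within the scatter of both compound 1 and compound 2: the single one-place step, a 1.6-fold higher number from compound 2 to compound 3 (0.21 log units; within the scatter), is within the scatter, and the gap to compound 1 is smaller still. Nothing among the three numbers separates one compound from another.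

The next compound, compound 4 `Cc1nc2nccc-2c(NCC(C)O)[nH]1`, carries 2-hydroxypropyl in place of isopropyl on a nitrogen on an aromatic ring. Among the measured compounds shown here, the only measured step that touches the same position is the one from compound 2 to compound 3, which exchanged propyl for isopropyl on that nitrogen and moved the number by an amount within the scatter. For the measured compounds named here, no measured step introduces a hydroxyl or any hydrogen-bond donor or acceptor on this chain, so there is no measured ground for a step beyond the scatter in either direction. The expected step in this assay is therefore a 1.1-fold lower number from compound 3 to compound 4 (0.04 log units; within the scatter), that is none beyond the scatter. Compound 4 is estimated at 500000000 nM, with a range of 200000000 nM to 1250000000 nM.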

Compound 4, half-maximal inhibitory concentration: 30200000 nM
Compound 4: the middle estimate sits 17-fold (1.22 log units) above what was measured, outside the stated range (below it).
By their numbers in this assay, from the lowest: compound 4; then compounds 2, 1 and 3 (each within the scatter of the next).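

Working notes on the amine chain: in this assay this nitrogen on an aromatic ring is no longer a silent position, since the change from propyl to isopropyl gave only a 1.6-fold higher number from compound 2 to compound 3 (0.21 log units; within the scatter) while 2-hydroxypropyl in place of isopropyl gives an 18-fold lower number from compound 3 to compound 4 (1.26 log units; beyond the scatter) and so a clear gain in inhibition. Among these compounds, the cleanest reading is the single change of hydroxy in place of hydrogen on a saturated chain carbon, which gives an 11-fold lower number from compound 2 to compound 4 (1.05 log units; beyond the scatter) with the rest of the chain unchanged, so the large step travels with the hydroxyl and not with the branching seen in the earlier pair. No supporting data bear on how the hydroxyl produces this gain.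

The compounds shown leave open whether the oxygen needs its hydrogen, which a methoxy group on the same chain carbon would test, and whether an amine in place of the hydroxyl gives a step of similar size. They also leave open how the step depends on where the hydroxyl sits, as on a longer chain with the hydroxyl at its end, and whether it carries over to the core of compound 1.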